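Aryl variation in a chromone series: notes toward compound 4

The source may hold more compounds than are shown below. What is called first, only, known or untested is meant among the compounds shown, and "the series" means these compounds.

Measured compounds:
compound 1 `CCC1=C(O)c2c(oc(-c3ccc(C)cc3)cc2=O)C(CC)(CC)C1=O` — 39.2 uM
compound 2 `CCC1=C(O)c2c(oc(-c3ccc(F)cc3)cc2=O)C(CC)(CC)C1=O` — 33 uM
compound 3 `CCC1=C(O)c2c(oc(-c3ccc(OC)cc3C)cc2=O)C(CC)(CC)C1=O` — 20.9 uM

In a functional assay on KB cells (Homo sapiens) for antiproliferative activity, read by sulforhodamine B assay, with a stated time of 3 days (on this read-out higher numbers stand for an effect only at larger amounts of compound and lower numbers for an effect already at smaller amounts), all three measured compounds fall close together. Compound 3 carries the lowest number of the three, yet a 1.9-fold lower number from compound 1 to compound 3 (0.27 log units; within the scatter) and a 1.6-fold lower number from compound 2 to compound 3 (0.20 log units; within the scatter) are both within the scatter, so no separation among the three is established. Compound 4 `CCC1=C(O)c2c(oc(-c3ccc(F)c(C)c3)cc2=O)C(CC)(CC)C1=O` is the next aryl variant, (4-fluoro-3-methylphenyl in place of 4-methoxy-2-methylphenyl on an aromatic carbon). Going by the values given here, the steps that bear on it are a 1.2-fold lower number from compound 1 to compound 2 (0.07 log units; within the scatter), an exchange of fluoro for methyl that changed nothing beyond the scatter, together with the two aryl swaps already noted. On this basis no step beyond the scatter is expected, and compound 4 is estimated at 30 uM (range 12 uM to 75 uM), a change of a 1.4-fold higher number from compound 3 to compound 4 (0.16 log units; within the scatter) expected from compound 3.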

Compound 4, concentration for half-maximal effect: 40.5 uM
Estimate against measurement, compound 4: 1.4-fold (0.13 log units) below; measured number inside the range.
By their numbers in this assay, from the lowest: compounds 3, 2, 1 and 4 (each within the scatter of the next).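

In this assay, the 4-fluoro-3-methylphenyl group brings no separation from any of the three earlier aryl groups: a 1.9-fold higher number from compound 3 to compound 4 (0.29 log units; within the scatter) and a 1.2-fold higher number from compound 2 to compound 4 (0.09 log units; within the scatter) and a 1.0-fold higher number from compound 1 to compound 4 (0.01 log units; within the scatter) all remain small steps. Methyl in place of hydrogen on the 4-fluorophenyl group thus adds no step beyond the scatter, and all four aryl groups at this position remain unseparated. Nothing measured here offers an explanation for these numbers.

Still open, going by these compounds, is whether an amine or a carboxylic acid on this aryl ring would move the number beyond the scatter. The same holds for a longer chain in place of the aryl ring.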